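Adding a Chloro Group to the Phenoxy Ring of Compound 3

A few compounds are considered here, and "the series" means these few. Any claim that something is new, unique, unknown or untested is made for them only; others in the source may bear on it.

Three compounds share one core and differ only in the group attached to it. Compound 1 `Cc1cc(Sc2ccccc2)c(S(C)(=O)=O)cc1C(=O)N=C(N)N` carries a phenylsulfanyl group and gives 14 nM in a functional assay for inhibition of sodium/hydrogen exchanger (Oryctolagus cuniculus); on this read-out higher numbers stand for weaker inhibition and lower numbers for stronger inhibition. Compound 2 `CCOc1cc(C)c(C(=O)N=C(N)N)cc1S(C)(=O)=O` carries an ethoxy group in that position and gives 19 nM in this assay. Compound 3 `Cc1cc(Oc2ccccc2)c(S(C)(=O)=O)cc1C(=O)N=C(N)N` carries a phenoxy group and gives 10 nM. The three numbers sit close together: a 1.4-fold higher number from compound 1 to compound 2 (0.13 log units; within the scatter), a 1.4-fold lower number from compound 1 to compound 3 (0.15 log units; within the scatter) and a 1.9-fold lower number from compound 2 to compound 3 (0.28 log units; within the scatter). Compound 3 stands at the low end of the three numbers shown, yet its distance to compound 1 and to compound 2 stays within the scatter, so no ranking among them can be drawn from these data.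

Compound 4 `Cc1cc(Oc2ccc(Cl)cc2)c(S(C)(=O)=O)cc1C(=O)N=C(N)N` keeps the phenoxy group of compound 3 and adds (chloro in place of hydrogen on an aromatic carbon). For the measured compounds named here, none of the measured steps touches a substituent on that outer ring; each of them exchanges the whole group on the core. Those exchanges left the read-out within the scatter, which gives no reason to expect a larger move from this change. For compound 4 the expected value in this assay is 10 nM, within 4 nM to 25 nM. The expected step is no change at the digits printed from compound 3 to compound 4 (within the scatter).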

Compound 4, half-maximal inhibitory concentration: 13 nM
Beside the measured number, compound 4's estimate is 1.3-fold (0.11 log units) below it, and the stated range covers the measured number.
By their numbers in this assay, from the lowest: compounds 3, 4, 1 and 2 (each within the scatter of the next).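

This is the first change shown on the outer ring of the phenoxy group rather than an exchange of the whole group on the core. A chloro group para to a large group, replacing hydrogen, leaves this assay within the scatter (a 1.3-fold higher number from compound 3 to compound 4 (0.11 log units; within the scatter)), so this position accepts a single chlorine atom with no measurable change in the read-out. The complete 4-chlorophenoxy group also cannot be told apart from the ethoxy group (a 1.5-fold lower number from compound 2 to compound 4 (0.16 log units; within the scatter)) or the phenylsulfanyl group (a 1.1-fold lower number from compound 1 to compound 4 (0.03 log units; within the scatter)), which means that the four compounds still give no ranking, and no supporting data are available to explain this flat result.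

A single chloro group cannot show how much this position tolerates in general, so an amine, a carboxylic acid or a longer chain at the same place could leave the number unchanged or move it well beyond the scatter. The compounds shown also leave open whether anything attached to this outer ring can shift the read-out at all.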